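Cyclohexyl for 2-methoxyphenyl: expected cytotoxicity of compound 3

A few compounds are considered here, and "the series" means these few. Any claim that something is new, unique, unknown or untested is made for them only; others in the source may bear on it.

Two members of a shared core have so far been tested in an ADME assay on L6 cells (Rattus norvegicus) for cytotoxicity, read by fluorescence and resazurin assay, with a stated time of 72 h; on this read-out higher numbers stand for an effect only at larger amounts of compound and lower numbers for an effect already at smaller amounts. Compound 1 `Cc1ccccc1-c1nc(=O)[nH]c2ccc(-c3cc[nH]n3)cc12` carries a methyl on an aromatic carbon of its pendant ring. In this assay compound 1 gives > 50000 nM, which is a limit of the assay and not a number. Compound 2 `COc1ccccc1-c1nc(=O)[nH]c2ccc(-c3cc[nH]n3)cc12` differs from compound 1 by a methoxy in place of methyl on an aromatic carbon. In this assay compound 2 gives > 50000 nM, again a limit rather than a measured value. Within the data shown here, the only step between measured compounds, a step that the two limits leave unreadable from compound 1 to compound 2, is therefore unreadable, since both values sit at the limit of > 50000 nM in this assay, at which 2 of the 2 values shown sit. Compound 2 thus stands at the edge of what this assay reports, with no number to rank it against compound 1.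

Compound 3 `O=c1nc(C2CCCCC2)c2cc(-c3cc[nH]n3)ccc2[nH]1` introduces a larger change, (cyclohexyl in place of 2-methoxyphenyl on an aromatic carbon). Among the measured compounds shown here, no measured step bears on this exchange, and the two anchors give no readable size of effect. Compound 3 is accordingly expected to give 60000 nM, with a range of 25000 nM to 200000 nM. The step that the limit leaves unreadable from compound 2 to compound 3 is estimated to be none beyond the scatter, most likely ending at the same limit.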

Compound 3, half-maximal effective concentration: > 50000 nM
Compound 3: only a limit was reported; the forecaster's own chance of this, stated with the estimate: 75%; the middle value is on the limit's open side.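

In this assay compound 3 gives > 50000 nM, a limit of the assay and not a number. Its steps from compound 1 and from compound 2 therefore cannot be read: the limit of > 50000 nM in this assay, at which 3 of the 3 values shown sit.

The compounds shown leave open at what concentration compound 1, compound 2 and compound 3 would produce an effect on this read-out, and whether those concentrations would differ.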